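This account rests on a few compounds, and the source may have more. Where it says the series, first, only, none or still open, it means among the compounds named here.

Compound 1 `FC(F)(F)Oc1ccc(-c2cn(Cc3ccccc3)c3c2CNCC3)cc1` in an assay on HEK293 cells for displacement of a labelled ligand from 5-hydroxytryptamine receptor 7 (Rattus norvegicus), with a stated time of 60 min (on this read-out higher numbers stand for weaker inhibition and lower numbers for stronger inhibition), gives 10000 nM. Among the compounds with values here, compound 2 `CC(C)(C)c1ccc(-c2cn(Cc3ccccc3)c3c2CNCC3)cc1` gives 10000 nM in this assay; the step of no change at the digits printed from compound 1 to compound 2 (within the scatter) is the only measured one, so compound 1 stands level with compound 2 and no compound is set apart. Compound 3 `Oc1ccc(-c2cn(Cc3ccccc3)c3c2CNCC3)cc1` carries the change (hydrogen in place of trifluoromethyl on an oxygen on an aromatic ring). Within the data shown here, no measured step covers this exchange: the step from compound 1 to compound 2 shows only that replacing the same trifluoromethoxy by tert-butyl left the value where it was. The expected step is therefore a 1.3-fold lower number from compound 1 to compound 3 (0.10 log units; within the scatter), with no direction favoured beyond the scatter. Compound 3 is estimated at 8000 nM, range 1500 nM to 20000 nM.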

Compound 3, inhibition constant: 10000 nM
Estimate against measurement, compound 3: 1.3-fold (0.10 log units) below; low and high end bracket the measured number.
By their numbers in this assay, from the lowest: compounds 1, 2 and 3 (each within the scatter of the next).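

The hydroxy compound gives no change at the digits printed from compound 1 to compound 3 (within the scatter) in this assay and no change at the digits printed from compound 2 to compound 3 (within the scatter) on the same read-out. At this aromatic carbon, hydroxy therefore stands level with trifluoromethoxy and tert-butyl, so the series now holds three different groups here with no separation in the number. No evidence bears on this flat result.

Going by these compounds, whether an amine or a carboxylic acid in this place would move the number stays open. So does whether any change elsewhere on the shared core would move it.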